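Dropping chloro from compound 2: expected cytotoxicity of compound 4

This account rests on a few compounds, and the source may have more. Where it says the series, first, only, none or still open, it means among the compounds named here.

Three compounds sharing one core were tested in an ADME assay on RD cells (Homo sapiens) for cytotoxicity; on this read-out higher numbers stand for lower toxicity in this test and lower numbers for higher toxicity in this test. Compound 1 `COc1ccc2c(c1)/C(=N/NC(=S)Nc1ccccc1)C(=O)N2` gives > 25000 nM, which is a limit of the assay and not a number. Compound 2 `O=C1Nc2ccccc2/C1=N/NC(=S)Nc1ccc(Cl)cc1` gives > 25000 nM, again only a limit. Compound 3 `COc1cccc(NC(=S)N/N=C2\C(=O)Nc3ccccc32)c1` gives > 25000 nM, also a limit. Compound 2 therefore stands at the limit of > 25000 nM in this assay, at which 3 of the 3 values shown sit, with nothing to set it apart from compound 1 or compound 3. Compound 4 `O=C1Nc2ccccc2/C1=N/NC(=S)Nc1ccccc1` differs from compound 2 by hydrogen in place of chloro on an aromatic carbon. Among the measured compounds shown here, no step between measured compounds exists here, so in this assay the size of this change can only be expected, and the expectation is none beyond the scatter. Compound 4 is thus expected to give about 40000 nM, between 20000 nM and 100000 nM, most likely reported again as a limit. The expected step is a step that the limit leaves unreadable from compound 2 to compound 4.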

Compound 4, half-maximal cytotoxic concentration: > 25000 nM
Compound 4 gave a limit, no number (the forecaster's own chance of this, stated with the estimate: 85%); the middle value does not contradict the limit.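

No step can be read from compound 1, compound 2 or compound 3 to compound 4, as all four give only a limit: the limit of > 25000 nM in this assay, at which 4 of the 4 values shown sit.

The compounds shown leave open how far apart these four truly lie, and which change to the shared core would yield a number.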